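The compounds below may be only part of what the source reports. "The series", "measured", "known", "first", "only" and "open" are said of these compounds alone.

In a functional assay on CWR22R cells (Homo sapiens) for cytotoxicity, read by MTT assay, with a stated time of 72 h (a lower number here means a stronger inhibitor, a higher number a weaker inhibitor), compound 1 `CC1=C(/C=C/C(=O)/C=C/c2ccccc2F)C(C)(C)CCC1O` gives 3300 nM; compound 2 `CC1=C(/C=C/C(=O)/C=C/c2cccc(F)c2)C(C)(C)CCC1O` gives 5600 nM; compound 3 `CC1=C(/C=C/C(=O)/C=C/c2ccc(F)cc2)C(C)(C)CCC1O` gives 7500 nM.

These three compounds share one core and differ only in where a single fluoro sits on the phenyl ring. Compound 2 stands second highest of the three numbers. Its nearest neighbour is compound 3, with a 1.3-fold higher number from compound 2 to compound 3 (0.13 log units; within the scatter), and its furthest is compound 1, with a 1.7-fold higher number from compound 1 to compound 2 (0.23 log units; within the scatter). Only the move from compound 1 to compound 3 reaches beyond the scatter, a 2.3-fold higher number from compound 1 to compound 3 (0.36 log units; beyond the scatter).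

Compound 4 `CC1=C(/C=C/C(=O)/C=C/c2cccc([N+](=O)[O-])c2)C(C)(C)CCC1O` keeps everything of compound 2 except one change: nitro in place of fluoro on an aromatic carbon. Going by the values given here, none of the measured steps swaps fluoro for another group; all three merely shift the fluoro around the ring, and each is small. They show only that moving the fluoro goes with at most a modest shift in this assay, and they say nothing directly about a nitro group. The change is therefore expected to bring a small step, likely within the scatter, a 1.1-fold lower number from compound 2 to compound 4 (0.05 log units; within the scatter). Compound 4 is estimated at 5000 nM in this assay, with a range from 2000 nM to 14000 nM.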

Compound 4, half-maximal inhibitory concentration: 1900 nM
Compound 4: the middle estimate sits 2.6-fold (0.42 log units) above what was measured; measured number below the stated range.
By their numbers in this assay, from the lowest: compounds 4, 1, 2 and 3 (each within the scatter of the next, the first and the last beyond it).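

In this assay, putting nitro in place of fluoro on this aromatic carbon brings a 2.9-fold lower number from compound 2 to compound 4 (0.47 log units; beyond the scatter). The earlier steps shown here only moved one fluoro around the ring, whereas this step exchanges the group itself, and it shows that the identity of the group at this place can shift the number by a modest amount beyond the scatter. No measurement shown here gives a reason for this shift.

The compounds shown carry only fluoro or nitro on this ring, so it remains open how an amine, a carboxylic acid or a longer chain on the same carbon would behave. Going by these compounds, it is also open whether nitro would give a similar step at other places on the ring, since a single exchange at one place cannot establish a trend.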